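From diisopropylamino to pyrrolidin-1-yl on a shared core

The source may report more compounds than this note shows. Statements on the series, on what has been measured and on what is new or still open speak of the compounds shown alone.

Measured in a functional assay on SMMC-7721 cells (Homo sapiens) for antiproliferative activity, read by MTT assay, with a stated time of 48 h; a lower number here means a stronger inhibitor, a higher number a weaker inhibitor:
Compound 1 `COC/C1=C/C[C@](C)(CCC=C(C)C)/C=C/[C@@H](OC(=O)C=C(C)C)[C@](C)(O)/C=C/C1=O` gives 11000 nM
Compound 2 `CC(C)=CCC[C@]1(C)/C=C/[C@@H](OC(=O)C=C(C)C)[C@](C)(O)/C=C/C(=O)/C(C(=O)O)=C\C1` gives > 10000 nM (a limit of the assay)
Compound 3 `CC(C)=CCC[C@]1(C)/C=C/[C@@H](OC(=O)C=C(C)C)[C@](C)(O)/C=C/C(=O)/C(CN(C(C)C)C(C)C)=C\C1` gives 340 nM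

Compound 3 holds the lowest of the two actual numbers in this assay. Compound 2 reads > 10000 nM, which is a limit of the assay and not a number. Going by the values given here, the gap to the one other number is the step of a 32-fold lower number from compound 1 to compound 3 (1.51 log units; beyond the scatter), and the step against the limit is an at least 29-fold lower number from compound 2 to compound 3 (1.46 log units; beyond the scatter).

The next compound is compound 4 `CC(C)=CCC[C@]1(C)/C=C/[C@@H](OC(=O)C=C(C)C)[C@](C)(O)/C=C/C(=O)/C(CN2CCCC2)=C\C1`, and the change is pyrrolidin-1-yl in place of diisopropylamino on a saturated chain carbon bound to a double-bonded ring carbon, in words pyrrolidin-1-yl in place of diisopropylamino. Both measured steps into compound 3 are large, but they replace methoxy and carboxy, and neither exchanges one amino group for another. Their size therefore does not carry over to this change. They offer no reason to expect a large move, so the expectation stays close to compound 3 at 340 nM, leaning slightly towards a higher number. In this assay no change beyond the scatter is expected, and the estimated size is a 1.5-fold higher number from compound 3 to compound 4 (0.17 log units; within the scatter). For compound 4 the expected value is 500 nM, with an estimated range from 150 nM to 2000 nM.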

Compound 4, half-maximal inhibitory concentration: 140 nM
For compound 4 the middle estimate is 3.6-fold (0.55 log units) above the measured one, outside the stated range (below it).
By their numbers in this assay, from the lowest: compound 4; then compound 3; then compound 1.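

In this assay, going by these compounds alone, the step of a 2.4-fold lower number from compound 3 to compound 4 (0.39 log units; beyond the scatter) is the first exchange of one amino group for another on this saturated chain carbon, and it shows that the number depends on which amino group stands there, not merely on an amino group being present. The change from methoxy gives a 79-fold lower number from compound 1 to compound 4 (1.90 log units; beyond the scatter), so pyrrolidin-1-yl also retains the large gain over methoxy that diisopropylamino showed. Compound 2 reads as a limit of the assay and not a number, so the comparison with carboxy gives only a bound, an at least 71-fold lower number from compound 2 to compound 4 (1.85 log units; beyond the scatter): the limit of > 10000 nM in this assay, at which 1 of the 4 values shown sits.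

The group that enters has fewer heavy atoms than the one that leaves and also carries a ring, while the donor and acceptor counts stay the same, so this single pair cannot separate ring from size. Going by these compounds, how the number would move with piperidin-1-yl or morpholin-4-yl, or with an open-chain dimethylamino, on the same carbon remains open.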